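From propyl to isopropyl: a small branching change

The source may report more compounds than this note shows. Statements on the series, on what has been measured and on what is new or still open speak of the compounds shown alone.

- compound 1 `COC(=O)C#CC(O/C=C/C(=O)OC)C(C)c1ccccc1`: 1200 nM
- compound 2 `CCCC(C#CC(=O)OC)O/C=C/C(=O)OC`: 320 nM
- compound 3 `CCCCCCCCCCC(C#CC(=O)OC)O/C=C/C(=O)OC`: 2000 nM

All three values come from a functional assay on SW1573 cells (Homo sapiens) for antiproliferative activity, read by sulforhodamine B assay, with a stated time of 48 h; a lower number here means a stronger inhibitor of growth, a higher number a weaker inhibitor of growth. Compound 2 has the lowest number of the three, and the other two sit beyond the scatter from it. The next compound to be tested is compound 4 `COC(=O)C#CC(O/C=C/C(=O)OC)C(C)C`. It has the same atoms as compound 2, joined differently: isopropyl in place of propyl on a saturated chain carbon bound to an oxygen on an unsaturated carbon and a triple-bonded carbon. The swap sits on a saturated chain carbon bound to an oxygen on an unsaturated carbon and a triple-bonded carbon.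

Within the data shown here, no measured step swaps propyl for isopropyl directly. The closest measured step, a modest one beyond the scatter, is the chain extension with heptyl in place of hydrogen: a 6.3-fold higher number from compound 2 to compound 3 (0.80 log units; beyond the scatter). Compound 1 also has a branched group at this carbon, but it differs from compound 4 by more than branching, and compound 1 gives 1200 nM. These two comparisons offer only a weak hint, and both point towards a higher number. The swap only rearranges the same atoms. A smaller step than a 6.3-fold higher number from compound 2 to compound 3 (0.80 log units; beyond the scatter) is expected, perhaps none beyond the scatter.

The estimated step is a 1.6-fold higher number from compound 2 to compound 4 (0.19 log units; within the scatter). For compound 4 the expected value is 500 nM, with an estimated range of 200 nM to 1300 nM.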

Compound 4, concentration for 50% growth inhibition: 750 nM
Compound 4: the middle estimate sits 1.5-fold (0.18 log units) below what was measured, and the stated range covers the measured number.
By their numbers in this assay, from the lowest: compound 2; then compounds 4, 1 and 3 (each within the scatter of the next, the first and the last beyond it).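

In this assay, isopropyl in place of propyl gives a 2.3-fold higher number from compound 2 to compound 4 (0.37 log units; beyond the scatter); the atoms stay the same and only the way they are joined changes, yet this alone moves the number beyond the scatter, so the position responds to branching as well as to the chain extension seen earlier. Once the group at this carbon is branched, the phenyl of compound 1 can be exchanged for the methyl of compound 4 with no readable effect: methyl in place of phenyl on a saturated chain carbon bound to two saturated chain carbons gives a 1.6-fold lower number from compound 1 to compound 4 (0.20 log units; within the scatter), which stays within the scatter. The data shown offer no measured reason why branching gives the higher number here.

As far as these compounds go, it remains open whether a tert-butyl or cyclopropyl group at this carbon would follow isopropyl or stay closer to propyl. From the compounds shown here alone, it is also open whether a straight butyl or hexyl chain would place the lowest number somewhere other than at propyl, and whether an amine or a carboxylic acid at the end of the chain would be tolerated.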